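Adding a Methoxy Group: From Compound 3 to Compound 4

A few compounds are considered here, and "the series" means these few. Any claim that something is new, unique, unknown or untested is made for them only; others in the source may bear on it.

Compound 1 `COc1ccc(-c2nc(C)c(C(=O)CSc3nc(-c4ccc(OC)cc4)c(C#N)c(=O)[nH]3)s2)cc1`: 11.5%
Compound 2 `COc1ccc(-c2nc(C)c(C(=O)CSc3nc(-c4ccc(OC)c(OC)c4)c(C#N)c(=O)[nH]3)s2)cc1`: 5.39%
Compound 3 `Cc1nc(-c2ccccc2)sc1C(=O)CSc1nc(-c2ccc(Cl)c(Cl)c2)c(C#N)c(=O)[nH]1`: 24.4%

Of the compounds shown here, three have been measured in a functional assay on U-87MG ATCC cells for antiproliferative activity against U-87 MG (Homo sapiens), read by MTT assay, with a stated time of 48 h, tested at 100 uM; a lower number here means a stronger effect, a higher number a weaker effect of the compound at the concentration tested. Compound 3 gives 24.4%, the highest of the three numbers, and its gaps to compound 1 and to compound 2 both lie beyond the scatter. Compound 4 `COc1ccc(-c2nc(C)c(C(=O)CSc3nc(-c4ccc(Cl)c(Cl)c4)c(C#N)c(=O)[nH]3)s2)cc1` has not been measured yet; it differs from compound 3 in one place: methoxy in place of hydrogen on an aromatic carbon. Going by the values given here, only one measured step shows a change of the same kind, methoxy in place of hydrogen on an aromatic carbon, and that step was small: a number 6.1 percentage points lower from compound 1 to compound 2 (within the scatter). On that basis no change beyond the scatter is expected, and the estimated step is a number 5.4 percentage points lower from compound 3 to compound 4 (within the scatter). Compound 4 is therefore expected to give about 19%, with a range from 8% to 31%.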

Compound 4, a percentage reported as activity, at one concentration (the size of the read-out at that concentration, not a potency): 31.1%
Compound 4: middle estimate off by 12.1 percentage points, on the low side, outside the stated range (above it).
By their numbers in this assay, from the lowest: compounds 2 and 1 (each within the scatter of the next); then compounds 3 and 4 (each within the scatter of the next).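

The methoxy group, para to a large group on the phenyl ring, gives a number 6.7 percentage points higher from compound 3 to compound 4 (within the scatter) in this assay. This change has now been read on two cores, and neither step stands out from the scatter: the same change on two cores in this assay, a number 6.1 percentage points lower (within the scatter) from compound 1 to compound 2 and a number 6.7 percentage points higher (within the scatter) from compound 3 to compound 4, 12.8 percentage points apart, within the scatter of two such steps

A larger difference appears at the other phenyl ring, where 3,4-dichlorophenyl in place of 3,4-dimethoxyphenyl gives a number 25.7 percentage points higher from compound 2 to compound 4 (beyond the scatter), and in place of 4-methoxyphenyl gives a number 19.6 percentage points higher from compound 1 to compound 4 (beyond the scatter).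

Still open, going by these compounds, is whether an amine or a carboxylic acid at the methoxy position would give a step beyond the scatter.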